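The source may hold more compounds than are shown below. What is called first, only, known or untested is meant among the compounds shown, and "the series" means these compounds.

Of the compounds shown here, three sharing one core have been measured in a functional assay on DU-145 cells (Homo sapiens) for inhibition, read by trypan blue exclusion, with a stated time of 96 h (a higher number here means a weaker inhibitor of growth, a lower number a stronger inhibitor of growth), and they differ only in the aromatic group on the double-bonded chain carbon. Compound 3 `COc1ccccc1/C=C(\C(=O)c1ccc(Cl)cc1)S(=O)(=O)Cc1ccc(C)cc1`, carrying 2-methoxyphenyl there, gives 10000 nM. Compound 1 `CSc1ccc(/C=C(\C(=O)c2ccc(Cl)cc2)S(=O)(=O)Cc2ccc(C)cc2)cc1`, carrying 4-(methylsulfanyl)phenyl, gives 10000 nM, which puts compound 3 level with it. Compound 2 `Cc1ccc(CS(=O)(=O)/C(=C/c2cccc(Cl)c2Cl)C(=O)c2ccc(Cl)cc2)cc1`, carrying 2,3-dichlorophenyl, gives 1000 nM, clearly lower than the other two.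

Compound 4 `Cc1ccc(CS(=O)(=O)/C(=C/c2ccccc2Br)C(=O)c2ccc(Cl)cc2)cc1` comes from compound 3 by a single swap: bromo in place of methoxy on an aromatic carbon, turning 2-methoxyphenyl into 2-bromophenyl. Among the compounds with values here, no measured compound carries bromo, so the guidance is indirect. The nearest measured change is a 10-fold higher number from compound 2 to compound 3 (1.00 log units; beyond the scatter), which involves the same 2-methoxyphenyl group, and its mirror image suggests that removing methoxy could help. The other steps are a 10-fold lower number from compound 1 to compound 2 (1.00 log units; beyond the scatter) and no change at the digits printed from compound 1 to compound 3 (within the scatter). That last step is a warning: compound 1 also lacks methoxy, yet it shows no gain over compound 3. A move toward a lower number is therefore expected in this assay, but only part of the distance to compound 2. The estimated change is a 3.3-fold lower number from compound 3 to compound 4 (0.52 log units; beyond the scatter). For compound 4 the expected value is 3000 nM, with an estimated range from 800 nM to 10000 nM.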

Compound 4, concentration for 50% growth inhibition: 25000 nM
Estimate against measurement, compound 4: 8.3-fold (0.92 log units) below; measured number above the stated range.
By their numbers in this assay, from the lowest: compound 2; then compounds 1 and 3 (each within the scatter of the next); then compound 4.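

The swap of bromo for methoxy on this aromatic carbon gives a weaker inhibitor in this assay (a 2.5-fold higher number from compound 3 to compound 4 (0.40 log units; beyond the scatter)), so losing methoxy from this place does not by itself lower the number, and the 2-bromophenyl group is worse here than 2-methoxyphenyl. Nor does one bromo on this ring come close to the result of the 2,3-dichlorophenyl group, as the largest step in the set shows (a 25-fold higher number from compound 2 to compound 4 (1.40 log units; beyond the scatter)), and 2-bromophenyl also falls short of 4-(methylsulfanyl)phenyl (a 2.5-fold higher number from compound 1 to compound 4 (0.40 log units; beyond the scatter)), which leaves compound 4 the weakest inhibitor of the four and makes compound 2 stand out even more clearly as the only compound with a lower number. Nothing available explains why these aromatic groups rank in this order.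

On these data alone, what stays open is whether the low number of compound 2 needs both chloro groups of 2,3-dichlorophenyl, a question that 2-chlorophenyl and 3-chlorophenyl on the shared core would help to separate. It is also unknown how this place would respond to quite different groups on the ring, such as an amine or a carboxylic acid.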